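The source may hold more compounds than are shown below. What is called first, only, known or untested is meant among the compounds shown, and "the series" means these compounds.

Measured compounds in the series:

compound 1 `CC(C)(C)OC(=O)NCCCNC(=O)CN1CN(c2ccccc2)C2(CCN(C(=O)c3ccc(C4CCCCC4)cc3)CC2)C1=O`: 6000 nM
compound 2 `CC(C)(C)OC(=O)NCCCNC(=O)CN1CN(c2ccccc2)C2(CCN(C(=O)c3ccc(C(C)(C)C)cc3)CC2)C1=O`: 4500 nM
compound 3 `CC(C)(C)OC(=O)NCNC(=O)CN1CN(c2ccccc2)C2(CCN(C(=O)c3ccc(C4CCCCC4)cc3)CC2)C1=O`: 1700 nM

All three were run in an assay on HEK293 cells for displacement of a labelled ligand from NPC1-like intracellular cholesterol transporter 1 (Homo sapiens); a lower number here means a stronger inhibitor, a higher number a weaker inhibitor. Compound 2 holds the second highest of the three numbers. Its nearest neighbour is compound 1, and the step of a 1.3-fold lower number from compound 1 to compound 2 (0.12 log units; within the scatter) lies within the scatter, so the two cannot be ordered. Compound 3 stands furthest from compound 2 and gives the lower number of the pair, a gap that is beyond the scatter.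

Compound 4 `CC(C)(C)c1ccc(C(=O)N2CCC3(CC2)C(=O)N(CC(=O)N2CCCC(O)C2)CN3c2ccccc2)cc1` is the next compound to be run in this assay. It keeps the tert-butyl of compound 2 and differs from it at the other end: 3-hydroxypiperidin-1-yl in place of (3-((tert-butoxycarbonyl)amino)propyl)amino on a carbonyl carbon.

Within the data shown here, the only measured step that bears on this region is a 3.5-fold lower number from compound 1 to compound 3 (0.55 log units; beyond the scatter), where trimming the chain on the amide-type nitrogen gave a modest lowering. Among the measured compounds shown here, no measured pair shows the replacement of the whole chain by a hydroxypiperidinyl ring, so the carry-over is loose. A modest step downward is expected, with wide uncertainty.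

Compound 4 is therefore estimated at 2500 nM, with a range from 800 nM to 8000 nM. The step this estimate implies is expected to be a 1.8-fold lower number from compound 2 to compound 4 (0.26 log units; within the scatter).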

Compound 4, half-maximal inhibitory concentration: 12200 nM
Estimate against measurement, compound 4: 4.9-fold (0.69 log units) below; measured number outside the range, above it.
By their numbers in this assay, from the lowest: compound 3; then compounds 2 and 1 (each within the scatter of the next); then compound 4.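

In this assay the carbonyl carbon proves sensitive to exchange of the whole chain: 3-hydroxypiperidin-1-yl in place of (3-((tert-butoxycarbonyl)amino)propyl)amino gives a 2.7-fold higher number from compound 2 to compound 4 (0.43 log units; beyond the scatter), a change opposite in direction to the lowering from trimming the chain in a 3.5-fold lower number from compound 1 to compound 3 (0.55 log units; beyond the scatter), which was read on the cyclohexyl compounds. The open chain with its tert-butoxycarbonyl group is still not a condition for a measurable result, since compound 4 gives 12200 nM, and the step remains modest. No available evidence bears on the reason for this rise.

On these data alone, this single exchange removes the open chain and brings in both the ring and the hydroxyl group at once, so their separate contributions remain open, as does whether the same change would give a step of similar size with cyclohexyl on the aromatic carbon. Plain piperidin-1-yl on the same carbonyl carbon would bear on the role of the hydroxyl group, and a short chain ending in a free primary amine would bear on the role of the tert-butoxycarbonyl group.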